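The source may hold more compounds than are shown below. What is called first, only, known or untested is meant among the compounds shown, and "the series" means these compounds.

In an assay (Cricetulus griseus) for inhibition of aldehyde dehydrogenase, mitochondrial (Homo sapiens) (a lower number here means a stronger inhibitor, a higher number a weaker inhibitor), compound 1 `O=C(O)CCCCCCCOc1ccc2c(=O)c(-c3ccc(O)cc3)coc2c1` gives 40 nM. Compound 2 `O=c1c(-c2ccc(O)cc2)coc2cc(OCCCCCCO)ccc12` gives 120 nM, and compound 3 `O=c1c(-c2ccc(O)cc2)coc2cc(OCCCCCCCCCCCCO)ccc12` gives 1700 nM. The change from compound 3 to compound 1 is carboxy in place of 5-hydroxypentyl on a saturated chain carbon, seven bonds along the chain from an oxygen on an aromatic ring and it made a 43-fold lower number from compound 3 to compound 1 (1.63 log units; beyond the scatter). Compound 4 `O=C(O)COc1ccc2c(=O)c(-c3ccc(O)cc3)coc2c1` has not yet been measured in this assay; it differs from compound 2 by carboxy in place of 5-hydroxypentyl on a saturated chain carbon bound to an oxygen on an aromatic ring. The two cores themselves differ by hydroxy in place of 6-hydroxyhexyl on a saturated chain carbon, six bonds along the chain from an oxygen on an aromatic ring. The places of the two changes are not the same word for word: in the first the new group sits seven bonds along the chain from an oxygen on an aromatic ring, in the second on a saturated chain carbon bound to an oxygen on an aromatic ring, so this is the same kind of change rather than the same change. The step in this assay from compound 2 to compound 4 is expected to be a 2.4-fold lower number from compound 2 to compound 4 (0.38 log units; beyond the scatter), smaller than the earlier one, because compound 2 already gives 120 nM, not far from compound 1 at 40 nM. Compound 4 is therefore estimated at about 50 nM, between 10 nM and 300 nM.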

Compound 4, half-maximal inhibitory concentration: 1200 nM
Compound 4: middle estimate off by 24-fold (1.38 log units), on the low side; measured number above the stated range.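

In this assay, the same kind of change did not carry over from one core to the other, and its direction reversed: the same change on two cores in this assay, a 43-fold lower number (1.63 log units; beyond the scatter) from compound 3 to compound 1 and a 10-fold higher number (1.00 log units; beyond the scatter) from compound 2 to compound 4, 430-fold (2.63 log units) apart, beyond the scatter of two such steps

With carboxy on a saturated chain carbon bound to an oxygen on an aromatic ring, the result was a 10-fold higher number from compound 2 to compound 4 (1.00 log units; beyond the scatter), and setting that short carboxy compound against the long one gave a 30-fold higher number from compound 1 to compound 4 (1.48 log units; beyond the scatter), so carboxy alone does not secure a low number in this series. Going by these compounds alone, this shows that the effect of the change cannot be copied from one core to another here, but it rests on only two pairs and does not show why the steps differ or give a rule for chain length.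

Carboxy chains of lengths other than carboxymethyl and the chain of compound 1 remain open, so the point at which the number rises along such a chain cannot be located. Also open, going by these compounds, is how an amine or an amide at the chain end would compare with the hydroxy and carboxy ends.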